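A few compounds are considered here, and "the series" means these few. Any claim that something is new, unique, unknown or untested is made for them only; others in the source may bear on it.

Compound 1 `O=C1c2ccccc2C(=O)N1CCOC(=S)N(C(=O)c1ccc([N+](=O)[O-])cc1Cl)c1ccc(Cl)cc1`: 19000 nM
Compound 2 `Cc1ccc(N(C(=O)c2ccc(Cl)c(Cl)c2)C(=S)OCCN2C(=O)c3ccccc3C2=O)cc1`: 17000 nM
Compound 3 `COc1cccc(OC)c1C(=O)N(C(=S)OCCN1C(=O)c2ccccc2C1=O)c1ccc(C)cc1`: 36000 nM

In an ADME assay on MT4 cells (Homo sapiens) for cytotoxicity, read by MTT assay (a higher number here means that more compound is tolerated, a lower number that less compound is tolerated), compound 3 gives 36000 nM, which lies within the scatter of compound 1. Compound 4 `Cc1ccc(N(C(=O)c2ccc([N+](=O)[O-])cc2Cl)C(=S)OCCN2C(=O)c3ccccc3C2=O)cc1` differs from it at one place: 2-chloro-4-nitrophenyl in place of 2,6-dimethoxyphenyl on a carbonyl carbon. In words, 2-chloro-4-nitrophenyl stands in place of 2,6-dimethoxyphenyl on a carbonyl carbon. Within the data shown here, the one measured step at this place is a 2.1-fold higher number from compound 2 to compound 3 (0.33 log units; beyond the scatter), and it brought in the group that now leaves. Though it differs from compound 4 elsewhere, compound 1 carries the incoming group and gives 19000 nM. In this assay, among the measured compounds shown here, a small fall is therefore expected, no larger than that step: a 1.8-fold lower number from compound 3 to compound 4 (0.26 log units; within the scatter). For compound 4 the estimated value is 20000 nM, with an expected range of 10000 nM to 40000 nM.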

Compound 4, half-maximal cytotoxic concentration: 17000 nM
Compound 4: middle estimate off by 1.2-fold (0.07 log units), on the high side, and the stated range covers the measured number.
By their numbers in this assay, from the lowest: compounds 2, 4, 1 and 3 (each within the scatter of the next, the first and the last beyond it).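

In this assay, putting 2-chloro-4-nitrophenyl in place of 2,6-dimethoxyphenyl on a carbonyl carbon gives a 2.1-fold lower number from compound 3 to compound 4 (0.33 log units; beyond the scatter), the same size as the earlier step, while the same group in place of 3,4-dichlorophenyl gives no change at the digits printed from compound 2 to compound 4 (within the scatter), so only 2,6-dimethoxyphenyl stands apart among these groups. Methyl in place of chloro on an aromatic carbon gives a 1.1-fold lower number from compound 1 to compound 4 (0.05 log units; within the scatter) and leaves the number within the scatter. Nothing measured on these compounds bears on the reason for this difference. On these data alone, whether an aminophenyl or a carboxyphenyl group on the carbonyl carbon would shift the number remains open. So does whether a saturated ring such as cyclohexyl would behave like the aromatic groups.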